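Shifting a Methoxy Group: From Compound 1 to Compound 3

The source may hold more compounds than are shown below. What is called first, only, known or untested is meant among the compounds shown, and "the series" means these compounds.

Compound 1, with the structure `COc1ccccc1/C=C/C(=O)/C=C/c1ccc(OCc2cn(CCCCCOc3cc(=O)oc4ccccc34)nn2)c(OC)c1`, was tested in a functional assay on COLO 205 cells (Homo sapiens) for inhibition, read by sulforhodamine B assay, with a stated time of 48 h, tested at 50 uM; a higher number here means more inhibition of growth at the concentration tested, a lower number less inhibition of growth. In this assay compound 1 gives 30%, the lowest of the two numbers in hand. Going by the values given here, the other measured compound, compound 2 with the structure `COc1cc(/C=C/C(=O)/C=C/c2cccc3ccccc23)ccc1OCc1cn(CCOc2cc(=O)oc3ccccc23)nn1`, is built differently in more than one place, so no single step connects the two compounds; in this assay compound 2 gives 85%, a number beyond the scatter above that of compound 1.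

Compound 3, with the structure `COc1cccc(/C=C/C(=O)/C=C/c2ccc(OCc3cn(CCCCCOc4cc(=O)oc5ccccc45)nn3)c(OC)c2)c1`, is the compound still to be measured. It differs from compound 1 in one place: 3-methoxyphenyl in place of 2-methoxyphenyl on a double-bonded chain carbon bound to a double-bonded chain carbon The same atoms are kept and only joined differently. Among the compounds with values here, no measured pair shows what this kind of change does, so its size cannot be read from the data. The step expected in this assay is a number 5 percentage points higher from compound 1 to compound 3 (within the scatter), which is none beyond the scatter. Compound 3 is therefore estimated at 35%, with a range from 15% to 60%.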

Compound 3, percent growth inhibition at one concentration: 34%
For compound 3 the middle estimate is 1 percentage points above the measured one; the range from low to high includes it.
By their numbers in this assay, from the lowest: compounds 1 and 3 (each within the scatter of the next); then compound 2.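

Going by these compounds alone, compound 3 supplies the first step in this set that changes only one place: with 3-methoxyphenyl in place of 2-methoxyphenyl on a double-bonded chain carbon bound to a double-bonded chain carbon, this assay shows a number 4 percentage points higher from compound 1 to compound 3 (within the scatter). Both groups have the same atoms, so this pair isolates where the methoxy group sits on the phenyl ring, and in this measurement that choice does not separate compound 1 from compound 3. Nothing measured here gives a reason for this result.

From the compounds shown here alone, the pair says nothing about a group with different atoms at this place, such as 3-aminophenyl or 3-carboxyphenyl, so it remains unknown whether this place can tolerate a larger change than moving the methoxy group. Going by these compounds, compound 2 gives 85% in this assay, but it differs from compound 1 and compound 3 in more than one place, so its steps to them cannot be read and the structural feature behind its value remains open.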